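Swapping 4-chlorophenyl for 2-(methylamino)phenyl

This account rests on a few compounds, and the source may have more. Where it says the series, first, only, none or still open, it means among the compounds named here.

In a physicochemical assay for lipophilicity, read by HPLC, at pH 7.5 (on this read-out higher numbers stand for higher lipophilicity and lower numbers for lower lipophilicity), compound 3 `CC[C@@H](Nc1c(C#N)c(-c2ccc(-c3ccc(Cl)cc3)cc2)nc2cnccc12)C(N)=O` gives 3.1. Compound 2 `CC[C@@H](Nc1c(C#N)c(-c2ccc(-c3ccccc3N(C)C)cc2)nc2cnccc12)C(N)=O` gives 3.2, which leaves a number 0.10 log units lower from compound 2 to compound 3 (within the scatter). Compound 1 `CC[C@@H](Nc1c(C#N)c(-c2ccc(-c3ncccc3C)cc2)nc2cnccc12)C(N)=O` stands apart at 2, with a number 1.10 log units higher from compound 1 to compound 3 (beyond the scatter).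

Compound 4 `CC[C@@H](Nc1c(C#N)c(-c2ccc(-c3ccccc3NC)cc2)nc2cnccc12)C(N)=O` has 2-(methylamino)phenyl in place of 4-chlorophenyl on an aromatic carbon. The closest measured group by name is the 2-(dimethylamino)phenyl of compound 2. Large steps appear only on leaving the 3-methylpyridin-2-yl of compound 1, as in a number 1.20 log units higher from compound 1 to compound 2 (beyond the scatter), and that group plays no part in this change. The step expected here is therefore small, with no clear shift beyond the scatter: a number 0.20 log units lower from compound 3 to compound 4 (within the scatter). The estimated value for compound 4 is 2.9, within an expected range of 2.5 to 3.3.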

Compound 4, distribution coefficient: 2.5
Compound 4: middle estimate off by 0.40 log units, on the high side; the range from low to high includes it.
By their numbers in this assay, from the lowest: compound 1; then compound 4; then compounds 3 and 2 (each within the scatter of the next).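

In this assay, hydrogen in place of one methyl on the nitrogen of the 2-(dimethylamino)phenyl group is enough for a clear shift (a number 0.70 log units lower from compound 2 to compound 4 (beyond the scatter)), so a change of a single methyl counts at this position. The 2-(methylamino)phenyl group also separates from 4-chlorophenyl (a number 0.60 log units lower from compound 3 to compound 4 (beyond the scatter)) and from 3-methylpyridin-2-yl (a number 0.50 log units higher from compound 1 to compound 4 (beyond the scatter)), which puts compound 4 in the gap between compound 1 and the other two. No measurement here gives a reason for these shifts. Still open, from the compounds shown here alone, is where a plain 2-aminophenyl group, with hydrogen replacing the remaining methyl, or a 2-(ethylamino)phenyl group would fall.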